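A Dichlorophenyl Isomer Swap and Cell Tolerance

The source may hold more compounds than are shown below. What is called first, only, known or untested is meant among the compounds shown, and "the series" means these compounds.

Compound 1 `Cn1cc(S(=O)(=O)CC(=O)Nc2ccc(Cl)cc2Cl)c2ccccc21` was tested in an ADME assay on HEK-293T cells (Homo sapiens) for cytotoxicity, read by CCK-8 assay, with a stated time of 48 h; a lower number here means that less compound is tolerated, a higher number that more compound is tolerated. Compound 1 gives > 100000 nM, which is a limit of the assay rather than a measured number. Compound 2 `O=C(CSc1c[nH]c2ncccc12)Nc1ccc(Cl)c(Cl)c1` likewise gives > 100000 nM, a limit. Compound 3 `Cn1cc(SCC(=O)Nc2cccc(Cl)c2)c2ccccc21` also gives > 100000 nM, again a limit. Among the compounds with values here, every value so far rests at the limit of > 100000 nM in this assay, at which 3 of the 3 values shown sit, and compound 1 stands with the rest at that ceiling. Compound 4 `Cn1cc(S(=O)(=O)CC(=O)Nc2cccc(Cl)c2Cl)c2ccccc21` has not been measured. It differs from compound 1 in one way: 2,3-dichlorophenyl in place of 2,4-dichlorophenyl on an amide-type nitrogen. Within the data shown here, no step between two measured compounds is known, so the size of this change cannot be read from the numbers; no shift beyond the scatter is expected. In this assay compound 4 is expected to give 150000 nM, in the range 50000 nM to 500000 nM, an expected step that the limit leaves unreadable from compound 1 to compound 4.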

Compound 4, half-maximal cytotoxic concentration: > 100000 nM
Compound 4 ended at the assay's limit; the forecaster's own chance of this, stated with the estimate: 80%; the middle value does not contradict the limit.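

Compound 1 and compound 4 both rest at a limit, so no step between them can be read: the limit of > 100000 nM in this assay, at which 4 of the 4 values shown sit.

The compounds shown leave open whether 2,3-dichlorophenyl and 2,4-dichlorophenyl differ at all, and at what concentration any of these compounds would harm the cells.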